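Allyl on the oxygen of compound 1

This account rests on a few compounds, and the source may have more. Where it says the series, first, only, none or still open, it means among the compounds named here.

In a functional assay on HeLa cells (Homo sapiens) for cytotoxicity, read by sulforhodamine B assay, with a stated time of 48 h (on this read-out lower numbers stand for stronger inhibition and higher numbers for weaker inhibition), compound 1 (`O=C(c1cccnc1)c1cc(Cl)cc(Cl)c1O`) gives > 100000 nM as a limit of the assay and not a number. Compound 1 thus stands at the limit of > 100000 nM in this assay, at which 1 of the 3 values shown sits, and has no measured position beyond that.

In this assay compound 2 (`O=C(c1cccnc1)c1cc(Cl)ccc1O`) gives 24000 nM and compound 3 (`O=C(c1cccnc1)c1cccc(Cl)c1O`) gives 21000 nM for now. Hydrogen in place of chloro on an aromatic carbon gives an at least 4.1-fold lower number from compound 1 to compound 2 (0.61 log units; beyond the scatter) and an at least 4.7-fold lower number from compound 1 to compound 3 (0.67 log units; beyond the scatter) with both steps beyond the scatter.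

Compound 4 (`C=CCOc1c(Cl)cc(Cl)cc1C(=O)c1cccnc1`) keeps both chloro groups and carries allyl in place of hydrogen on an oxygen on an aromatic ring. Among the measured compounds shown here, neither measured step touches that oxygen, and no step for this change has been measured. For the measured compounds named here, they show only that one change can bring compound 1 to a number, as in an at least 4.7-fold lower number from compound 1 to compound 3 (0.67 log units; beyond the scatter) with a different change. A modest move to a lower number in this assay is therefore expected, with a reading at the limit still quite possible.

The expected step is an at least 2.0-fold lower number from compound 1 to compound 4 (0.30 log units; that floor lies within the scatter) and it is loosely held.

For compound 4 the estimated value is 50000 nM with an expected range of 15000 nM to 150000 nM in this series.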

Compound 4, half-maximal inhibitory concentration: 34000 nM
Compound 4: middle estimate off by 1.5-fold (0.17 log units), on the high side; low and high end bracket the measured number.
By their numbers in this assay, from the lowest: compounds 3, 2 and 4 (each within the scatter of the next). At a limit, above all of these: compound 1.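

Allyl in place of hydrogen on an oxygen on an aromatic ring gives an at least 2.9-fold lower number from compound 1 to compound 4 (0.46 log units; beyond the scatter) in this assay, so this oxygen is a place where a change brings the series from a limit to a number with both chloro groups kept. The earlier steps shown here reached a number only by removing a chloro group, whereas compound 4 shows that the hydroxy hydrogen of compound 1 is not required for a measured value. The step is only a floor, because compound 1 stands at a limit of the assay: the limit of > 100000 nM in this assay, at which 1 of the 4 values shown sits.

Going by these compounds, whether allyl itself matters, or whether other groups on this oxygen such as methyl, benzyl or a longer chain carrying an amine would serve equally, stays open. Also open, on these data alone, is what allyl would do on the oxygen of compound 2 or compound 3, where the starting values are numbers.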